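Geometry switch on the unsaturated acid of compound 1

The source may report more compounds than this note shows. Statements on the series, on what has been measured and on what is new or still open speak of the compounds shown alone.

Three compounds of this series have a number in a physicochemical assay for lipophilicity; a lower number here means a more polar compound, a higher number a more lipophilic compound. Compound 1 `C/C(=C\C(=O)O)C(=O)c1ccc(C)cc1` gives 2.94 in this assay, which is the second highest of the three. Compound 3 `COC(=O)/C=C/C(=O)c1ccc(C)cc1` gives 2.74 in this assay, and the two numbers lie within the scatter of each other. Compound 2 `CCCCCCCCCCCC(=O)/C(C)=C(/C)C(=O)O` gives 4.4 in this assay, the highest of the three and beyond the scatter above compound 1.

Compound 4 `C/C(=C/C(=O)O)C(=O)c1ccc(C)cc1` is the next compound to be measured in this assay. Against compound 1 the difference is the two compounds have the same atoms and bonds and differ only in configuration as drawn: 1 of 1 stereo elements differ; a double bond is drawn E in compound 1 and Z in compound 4. Going by the values given here, no pair of measured compounds differs only in the configuration of a double bond, so nothing measured here tells how large such a step is.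

The expectation for compound 4 is therefore a small change from compound 1, most likely none beyond the scatter, with a slight lean toward a lower number. The step from compound 1 to compound 4 is expected to be a number 0.14 log units lower from compound 1 to compound 4 (within the scatter) in this assay. Compound 4 is estimated at 2.8 in this assay, with a range from 2.3 to 3.3.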

Compound 4, partition coefficient: 2.19
Compound 4: the middle estimate sits 0.61 log units above what was measured, and the stated range ends above it.
By their numbers in this assay, from the lowest: compound 4; then compounds 3 and 1 (each within the scatter of the next); then compound 2.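

In this assay the series now holds its first measured step for configuration alone, a number 0.75 log units lower from compound 1 to compound 4 (beyond the scatter), so the geometry of this double bond cannot be treated as a neutral detail of the drawing. With nothing entering or leaving, the step can be placed on the double bond of the unsaturated acid and nowhere else, because of this: the fact that compounds 1 and 4 differ only in the configuration as drawn. The earlier compounds shown here formed no pair that differs in one place, so this one pair carries the whole reading of this position, and it shows that the position responds to geometry in this assay even with every atom unchanged.

The compounds shown do not tell whether a step of this size and direction is particular to the free acid, since a single pair cannot show whether the same switch would give a similar step with an amide in place of the carboxylic acid. As far as these compounds go, it also stays open whether the step holds when the core of compound 1 carries a different group, such as a hydroxyl or an amine, or whether the size of the step depends on the groups around the double bond.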